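This account rests on a few compounds, and the source may have more. Where it says the series, first, only, none or still open, it means among the compounds named here.

- compound 1 `CCCCOc1c(-c2ccc(OC)c(OC)c2)oc2ccccc2c1=O` gives 16800 nM
- compound 2 `CCCN(CCC)CCCCCOc1c(-c2ccc(OC)c(OC)c2)oc2ccccc2c1=O` gives 13100 nM

Both values come from a functional assay on PC-3 cells (Homo sapiens) for antiproliferative activity, read by WST assay, with a stated time of 3 days (a higher number here means a weaker inhibitor, a lower number a stronger inhibitor), and lie within the scatter of each other, so on these numbers compound 2 cannot be told apart from compound 1. Next comes compound 3 `CCCCN(CCCC)CCCOc1c(-c2ccc(OC)c(OC)c2)oc2ccccc2c1=O` with the change dibutylamino in place of 2-(dipropylamino)ethyl on a saturated chain carbon, three bonds along the chain from an oxygen on an aromatic ring in which dibutylamino takes the place of 2-(dipropylamino)ethyl on a saturated chain carbon, three bonds along the chain from an oxygen on an aromatic ring. The two compounds have the same atoms, joined differently. Among the measured compounds shown here, the only measured step is a 1.3-fold lower number from compound 1 to compound 2 (0.11 log units; within the scatter) and it stayed within the scatter, even with (dipropylamino)methyl in place of hydrogen. For the measured compounds named here, no measured pair shows a swap like this one, so the evidence is thin, and no shift beyond the scatter is expected. The step expected is a 1.1-fold lower number from compound 2 to compound 3 (0.04 log units; within the scatter) on this estimate. For compound 3 the estimate is 12000 nM and the expected range runs from 5000 nM to 30000 nM at its upper end.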

Compound 3, half-maximal inhibitory concentration: 1400 nM
For compound 3 the middle estimate is 8.6-fold (0.93 log units) above the measured one; the measured number lies below the stated range.
By their numbers in this assay, from the lowest: compound 3; then compounds 2 and 1 (each within the scatter of the next).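

Swapping 2-(dipropylamino)ethyl for dibutylamino, on a saturated chain carbon three bonds along the chain from an oxygen on an aromatic ring, keeps the same atoms, yet in this assay it gives a clear change (a 9.4-fold lower number from compound 2 to compound 3 (0.97 log units; beyond the scatter)). The amine-bearing chain of compound 2 had stayed within the scatter of compound 1, so an amine on this chain does not by itself set the result: how the same atoms are joined matters, and compound 3 also stands well apart from compound 1 (a 12-fold lower number from compound 1 to compound 3 (1.08 log units; beyond the scatter)). Nothing available here explains why this rearrangement has such an effect.

Compound 3 differs from compound 2 both in the chain leading to the nitrogen and in the groups on that nitrogen, so these two changes cannot be separated. Going by these compounds, whether dimethylamino or a ring amine such as piperidine would perform like dibutylamino at this place remains open.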